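The source may report more compounds than this note shows. Statements on the series, on what has been measured and on what is new or still open speak of the compounds shown alone.

Compound 1 `Cc1ccc(NC(=O)c2cccc(/C=C3\CC(=O)N(c4ccccc4)C3=O)c2)cc1C` in this assay: > 100000 nM
Compound 2 `CCOc1ccc(NC(=O)c2cccc(/C=C3\CC(=O)N(Cc4ccccc4)C3=O)c2)cc1` in this assay: 73200 nM

Both compounds were tested in an ADME assay on SW480 cells (Homo sapiens) for cytotoxicity, read by MTT assay, with a stated time of 72 h; a lower number here means a stronger inhibitor, a higher number a weaker inhibitor. For compound 1 the result > 100000 nM is a limit of the assay and not a number (the limit of > 100000 nM in this assay, at which 1 of the 2 values shown sits). Compound 2 gives a measured number, 73200 nM, so both compounds show only weak effects on the cells. Compound 3 `O=C(NCC1CCCCC1)c1cccc(/C=C2\CC(=O)N(c3ccccc3)C2=O)c1` has not yet been measured. It keeps the shared core of compound 1 and differs from it in one place: cyclohexylmethyl in place of 3,4-dimethylphenyl on an amide-type nitrogen. Going by the values given here, no step between two measured compounds is available to guide the size of this change, so only a rough expectation can be given. The expected step of a number no higher from compound 1 to compound 3 (the limit leaves the size open) is small, within the usual scatter of repeated measurements, with compound 3 likely to remain a weak inhibitor. Compound 3 is therefore estimated at 100000 nM, with a range from 40000 nM to 250000 nM.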

Compound 3, half-maximal inhibitory concentration: > 100000 nM
Compound 3: no number, only a limit; the forecaster's own chance of this, stated with the estimate: 50%; the middle value sits exactly at the limit.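

Compound 3 gives > 100000 nM, which is a limit and not a number, and compound 1 also stands at a limit, so no step from compound 1 to compound 3 can be read: the limit of > 100000 nM in this assay, at which 2 of the 3 values shown sit.

The compounds shown leave open whether cyclohexylmethyl in place of 3,4-dimethylphenyl changes the effect on the cells at all.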